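The source may hold more compounds than are shown below. What is called first, only, known or untested is meant among the compounds shown, and "the series" means these compounds.

Going by the values given here, compound 1, `CCN(c1ccc(C#N)c(Cl)c1)c1cc(-c2ccncc2)ccc1C`, is the only compound here with a number: in an ADME assay on L02 cells (Homo sapiens) for antiproliferative activity, read by CCK-8 assay, with a stated time of 6 days (a higher number here means a weaker inhibitor, a lower number a stronger inhibitor), compound 1 gives 1730 nM. Compound 2, `CCN(c1ccc(C#N)c(Cl)c1)c1cc(-c2ccc(F)nc2)ccc1C`, carries a 6-fluoropyridin-3-yl group on the shared core, but in this assay compound 2 gives "not determined" (no result reported), so compound 2 stands on no number at all. Compound 3, `CCN(c1ccc(C#N)c(Cl)c1)c1cc(-n2ccnc2)ccc1C`, is the next compound, and it differs from compound 2 in one place: 1H-imidazol-1-yl in place of 6-fluoropyridin-3-yl on an aromatic carbon. Among the compounds with values here, since compound 2 has no value, no step between measured compounds can be given, and the size of this step in this assay is open. The closest anchor is compound 1 in this assay at 1730 nM. With that anchor, and with the ring change counted above, compound 3 is expected to land near 3000 nM in this assay, with a range from 800 nM to 12000 nM.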

Compound 3, half-maximal inhibitory concentration: 15000 nM
Beside the measured number, compound 3's estimate is 5.0-fold (0.70 log units) below it; measured number outside the range, above it.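

On the shared core, putting 1H-imidazol-1-yl in place of pyridin-4-yl at this position gives an 8.7-fold higher number from compound 1 to compound 3 (0.94 log units; beyond the scatter) in this assay, a step beyond the usual scatter and toward weaker inhibition of these cells. Going by these compounds alone, this is the first measured sign that the two aromatic rings are not interchangeable here, and that the ring on this carbon can shift the result by a clear margin. Nothing shown here gives a reason for this shift.

From the compounds shown here alone, the step from compound 2 to compound 3 cannot be read, as compound 2 has no number, so the effect of 6-fluoropyridin-3-yl at this position remains unknown. Also open, going by these compounds, is how a group of another kind, such as a simple amine or a carboxylic acid, would behave on this carbon.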